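A few compounds are considered here, and "the series" means these few. Any claim that something is new, unique, unknown or untested is made for them only; others in the source may bear on it.

Compound 1 `COC(=O)C#CC(O/C=C/C(=O)OC)C1CC1`, compound 2 `CCCCCCCCCCC(C#CC(=O)OC)O/C=C/C(=O)OC` and compound 3 `Cc1ccc(S(=O)(=O)C#CC(O/C=C/S(=O)(=O)c2ccc(C)cc2)C(C)C)cc1` share one read-out, a functional assay on SW1573 cells (Homo sapiens) for antiproliferative activity, read by sulforhodamine B assay, with a stated time of 48 h; on this read-out higher numbers stand for weaker inhibition of growth and lower numbers for stronger inhibition of growth. In this assay compound 1 gives 1800 nM, compound 2 gives 2000 nM and compound 3 gives 3200 nM. Compound 2 sits within the scatter of both compound 1 and compound 3, so the three numbers cannot be told apart. Compound 4 `COC(=O)C#CC(CCc1ccccc1)O/C=C/C(=O)OC` has not been measured. It differs from compound 2 by phenyl in place of octyl on a saturated chain carbon, three bonds along the chain from an oxygen on an unsaturated carbon and a triple-bonded carbon. Since compound 1 and compound 2 carry very different groups at this carbon yet give numbers within the scatter, the step from compound 2 to compound 4 in this assay is expected to be small, with no direction beyond the scatter, namely no change at the digits printed from compound 2 to compound 4 (within the scatter). Compound 4 is therefore estimated at 2000 nM, in the range 900 nM to 4500 nM.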

Compound 4, concentration for 50% growth inhibition: 2600 nM
The estimate for compound 4 lay 1.3-fold (0.11 log units) below the measured number, and the stated range covers the measured number.
By their numbers in this assay, from the lowest: compounds 1, 2, 4 and 3 (each within the scatter of the next).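

In this assay the exchange of octyl for phenyl on this saturated chain carbon gives a 1.3-fold higher number from compound 2 to compound 4 (0.11 log units; within the scatter), the first step read between two compounds that differ in this one place. An aromatic ring can therefore stand here in place of an open chain with the read-out staying within the scatter. Nothing measured here bears on why this is so. The compounds shown leave open whether an amine or a carboxylic acid at this carbon would keep the number within that scatter. They also leave open whether a substituted phenyl would do so.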